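The source may report more compounds than this note shows. Statements on the series, on what has been measured and on what is new or still open speak of the compounds shown alone.

Measured compounds in a functional assay on MIA PaCa-2 cells (Homo sapiens) for inhibition, read by MTT assay, with a stated time of 72 h; on this read-out lower numbers stand for stronger inhibition of growth and higher numbers for weaker inhibition of growth: compound 1 `O=[N+]([O-])c1ccc(S(=O)(=O)NCCCCCCNCc2ccc(Br)cc2)cc1` gives 9800 nM; compound 2 `O=S(=O)(NCCCNCc1ccc(Cl)c(Cl)c1)c1cc(C(F)(F)F)cc(C(F)(F)F)c1` gives 2700 nM; compound 3 `CC(C)(C)c1ccc(CNCCNS(=O)(=O)c2cc(C(F)(F)F)cc(C(F)(F)F)c2)cc1` gives 15000 nM.

On these three numbers compound 2 stands lowest, with compound 1 the nearest and compound 3 the furthest; both gaps lie beyond the scatter. Compound 4 `O=S(=O)(NCCCNCc1ccc(Cl)cc1)c1cc(C(F)(F)F)cc(C(F)(F)F)c1` has not yet been measured in this assay. Compound 4 differs from compound 2 in one place, (hydrogen in place of chloro on an aromatic carbon). For the measured compounds named here, no measured pair shows this change, so its size is not known from the series. The step is expected to be a 1.9-fold higher number from compound 2 to compound 4 (0.27 log units; within the scatter), a modest move toward weaker inhibition of growth, close to the edge of the scatter. For compound 4 the expected value in this assay is 5000 nM, with a range from 2000 nM to 15000 nM.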

Compound 4, concentration for 50% growth inhibition: 2800 nM
Compound 4: middle estimate off by 1.8-fold (0.25 log units), on the high side, and the stated range covers the measured number.
By their numbers in this assay, from the lowest: compounds 2 and 4 (each within the scatter of the next); then compounds 1 and 3 (each within the scatter of the next).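

Hydrogen in place of chloro gives a 1.0-fold higher number from compound 2 to compound 4 (0.02 log units; within the scatter) in this assay, the first pair in the series that differs in one place. On this read-out, 3,4-dichlorobenzyl and 4-chlorobenzyl therefore cannot be told apart, so growth inhibition at the level of compound 2 does not depend on the chloro that leaves. No measurement at hand offers an explanation for this result. From the compounds shown here alone, it remains open whether the chloro left in compound 4 matters, which a methoxy group or a carboxylic acid in its place would test. Going by these compounds, whether the same step holds on a longer chain is also open.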